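Nitro for trifluoromethyl: expected inhibition of compound 4

The compounds below may be only part of what the source reports. "The series", "measured", "known", "first", "only" and "open" are said of these compounds alone.

Compound 3 `CCOC(=O)C1=C(Nc2cccc(C(F)(F)F)c2)S/C(=C\c2ccc[nH]2)C1=O` gives 19700 nM in a functional assay on JAR cells (Homo sapiens) for inhibition, read by MTT assay, with a stated time of 72 h; a lower number here means a stronger inhibitor, a higher number a weaker inhibitor; it stands within the scatter of compound 2 `CCOC(=O)C1=C(Nc2cccc(F)c2)S/C(=C\c2ccc[nH]2)C1=O` at 22600 nM and of compound 1 `CCOC(=O)C1=C(Nc2ccc(Br)cc2)S/C(=C\c2ccc[nH]2)C1=O` at 27000 nM. Compound 4 `CCOC(=O)C1=C(Nc2cccc([N+](=O)[O-])c2)S/C(=C\c2ccc[nH]2)C1=O` differs from compound 3 by nitro in place of trifluoromethyl on an aromatic carbon. The step that bears on this change is a 1.1-fold lower number from compound 2 to compound 3 (0.06 log units; within the scatter), a substituent swap on an aromatic carbon of the same ring; the other known step, a 1.2-fold lower number from compound 1 to compound 2 (0.08 log units; within the scatter), is flat as well. With both measured steps inside the scatter, no step beyond the scatter is expected in this assay for compound 4, and the expected step is a 1.0-fold higher number from compound 3 to compound 4 (0.01 log units; within the scatter). Compound 4 is therefore estimated at 20000 nM, with a range from 8000 nM to 50000 nM.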

Compound 4, half-maximal inhibitory concentration: 10100 nM
Beside the measured number, compound 4's estimate is 2.0-fold (0.30 log units) above it, and the stated range covers the measured number.
By their numbers in this assay, from the lowest: compounds 4, 3, 2 and 1 (each within the scatter of the next, the first and the last beyond it).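

In this assay the steps of a 2.2-fold lower number from compound 2 to compound 4 (0.35 log units; beyond the scatter) and a 2.7-fold lower number from compound 1 to compound 4 (0.43 log units; beyond the scatter) are the only ones in the series beyond the scatter, and both are modest. The direct swap gives a 2.0-fold lower number from compound 3 to compound 4 (0.29 log units; within the scatter) and stays within the scatter, so nitro and trifluoromethyl are not separated on this aromatic carbon. Nothing measured on hand accounts for these steps.

Open, going by these compounds, is how an amine, a nitrile or a carboxylic acid on the same aromatic carbon would read. Also open, on these data alone, is whether any group there moves the number beyond the scatter from compound 3.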